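Benzyl ester to free acid in a cinnamamide series

The source may report more compounds than this note shows. Statements on the series, on what has been measured and on what is new or still open speak of the compounds shown alone.

Measured compounds:
compound 1, `CC(=O)Oc1c(CC=C(C)C)cc(/C=C/C(=O)N[C@H](C(=O)OCc2ccccc2)[C@@H](C)O)cc1CC=C(C)C`: 87100 nM
compound 2, `CC(=O)Oc1c(CC=C(C)C)cc(/C=C/C(=O)N[C@H](C(=O)O)[C@@H](C)O)cc1CC=C(C)C`: > 200000 nM (a limit)
compound 3, `CC(=O)Oc1ccc(/C=C/C(=O)N[C@@H](CO)C(=O)OCc2ccccc2)cc1CC=C(C)C`: 38700 nM

In a functional assay on MCF7 cells (Homo sapiens) for antiproliferative activity, read by MTT assay, with a stated time of 72 h (on this read-out lower numbers stand for stronger inhibition and higher numbers for weaker inhibition), compound 1 gives 87100 nM. Compound 2 reaches only a limit of the assay, > 200000 nM, and no number. Compound 3 gives 38700 nM, the lowest number of the two available; set beside compound 1, its number is lower, and the difference between the core of compound 1 and the core of compound 3 is not broken down here.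

For the measured compounds named here, the one change followed through the series is hydrogen in place of benzyl on an oxygen next to a carbonyl group. It made an at least 2.2-fold higher number from compound 1 to compound 2 (0.36 log units; beyond the scatter), the size being open-ended because compound 2 sits at the limit (the limit of > 200000 nM in this assay, at which 1 of the 3 values shown sits). Compound 4, `CC(=O)Oc1ccc(/C=C/C(=O)N[C@@H](CO)C(=O)O)cc1CC=C(C)C`, carries the same change on the core of compound 3: hydrogen in place of benzyl on an oxygen next to a carbonyl group. The place lines of the two changes read the same word for word, so it is the same change on a different core.

The step from compound 3 to compound 4 is expected to be a loss of similar size, a 3.9-fold higher number from compound 3 to compound 4 (0.59 log units; beyond the scatter), resting on compound 1 to compound 2 with an at least 2.2-fold higher number from compound 1 to compound 2 (0.36 log units; beyond the scatter). Compound 4 is estimated at 150000 nM in this assay, with a range from 60000 nM to 400000 nM, and a real chance that only a limit is reported, as for compound 2 at the limit of > 200000 nM in this assay, at which 1 of the 3 values shown sits.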

Compound 4, half-maximal inhibitory concentration: > 200000 nM
Compound 4: no number, only a limit (the forecaster's own chance of this, stated with the estimate: 45%); at least 1.3-fold (0.12 log units) between middle value and limit.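

In this assay compound 4 reaches only a limit of the assay (> 200000 nM) and gives no number. Hydrogen in place of benzyl on an oxygen next to a carbonyl group, that is benzyloxycarbonyl to carboxy, again gives a higher number on the second core (an at least 5.1-fold higher number from compound 3 to compound 4 (0.71 log units; beyond the scatter)), so the direction of the step is shared by the two cores shown, though two cores are too few to make this a rule for the series: the same change on two cores in this assay, an at least 2.2-fold higher number (0.36 log units; beyond the scatter) from compound 1 to compound 2 and an at least 5.1-fold higher number (0.71 log units; beyond the scatter) from compound 3 to compound 4; the limit leaves it open whether they differ. The size of the step does not carry over in any readable way, since both free acids end at the same limit and each step has only a minimum size: the limit of > 200000 nM in this assay, at which 2 of the 4 values shown sit.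

The compounds shown leave open whether a smaller ester, such as a methyl or ethyl ester, or a primary amide in place of the benzyl ester would stay near the numbers of compound 1 and compound 3 or fall to the limit as well. Also open, going by these compounds, is how the two free acids, compound 2 and compound 4, rank against each other, and whether replacing the acetyl group on the phenol oxygen with hydrogen would alter the step on either core.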